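Opening the imidazolidinone of a weak quinoline amide

A few compounds are considered here, and "the series" means these few. Any claim that something is new, unique, unknown or untested is made for them only; others in the source may bear on it.

Compound 1 `COc1cc(NC(C)CCCN2C(=O)CN(C(=O)[C@H](C)N)C2(C)C)c2ncccc2c1` gives 46300 nM in a functional assay on HT-29 cells (Homo sapiens) for antiproliferative activity, read by sulforhodamine B assay, with a stated time of 48 h; on this read-out lower numbers stand for stronger inhibition and higher numbers for weaker inhibition. Compound 2 `COc1cc(NC(C)CCCNC(=O)CN2C(=O)[C@H](C)NC2(C)C)c2ncccc2c1` reaches only the limit of this assay, > 100000 nM, which is a limit and not a number; this is the limit of > 100000 nM in this assay, at which 1 of the 2 values shown sits. Compound 3 `COc1cc(NC(C)CCCNC(=O)CNC(=O)[C@H](C)N)c2ncccc2c1` differs from compound 2 by ((1-aminoethyl)carbonyl)amino in place of 2,2,4-trimethyl-5-oxoimidazolidin-1-yl on a saturated chain carbon bound to a carbonyl carbon. Among the compounds with values here, no measured pair spans this change, so the step from compound 2 to compound 3 in this assay is expected to be small, if anything toward stronger inhibition, and an outcome within the scatter would not surprise. Compound 3 is therefore estimated at 70000 nM, within 20000 nM to 200000 nM, a shift of an at least 1.4-fold lower number from compound 2 to compound 3 (0.15 log units; that floor lies within the scatter) that is expected rather than known.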

Compound 3, half-maximal inhibitory concentration: 92300 nM
Estimate against measurement, compound 3: 1.3-fold (0.12 log units) below; the range from low to high includes it.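

In this assay, ((1-aminoethyl)carbonyl)amino in place of 2,2,4-trimethyl-5-oxoimidazolidin-1-yl on a saturated chain carbon bound to a carbonyl carbon gives an at least 1.0-fold lower number from compound 2 to compound 3 (0.03 log units; that floor lies within the scatter). Losing this ring therefore brings compound 3 inside the measurable range, but shows no gain beyond the scatter. The real size of the step stays unknown because compound 2 is held only by a limit: the limit of > 100000 nM in this assay, at which 1 of the 3 values shown sits.

As far as these compounds go, whether a plain amine or a carboxylic acid on that same chain carbon would give a clearly lower number remains open.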